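This account rests on a few compounds, and the source may have more. Where it says the series, first, only, none or still open, it means among the compounds named here.

Within the data shown here, in a functional assay on HOS cells (Homo sapiens) for antiproliferative activity, read by sulforhodamine B assay (on this read-out higher numbers stand for weaker inhibition of growth and lower numbers for stronger inhibition of growth), compound 2 (`CC[C@@H]1O[C@H](COCc2ccccc2)[C@@H](OCc2ccccc2)[C@H](OCc2ccccc2)C1=O`) gives 4300 nM, the lower of the two numbers so far, while compound 1 (`CCC[C@@H]1O[C@H](COCc2ccc(F)cc2)[C@@H](OCc2ccc(F)cc2)[C@H](OCc2ccc(F)cc2)[C@H]1O`) gives 17200 nM, a gap beyond the scatter. Compound 3 (`O=C1[C@H](Cc2ccccc2)O[C@H](COCc2ccccc2)[C@@H](OCc2ccccc2)[C@@H]1OCc1ccccc1`) has not yet been measured. It departs from compound 2 in one place: phenyl in place of methyl on a saturated chain carbon bound to a saturated ring carbon. Among the measured compounds shown here, no measured step shows what this change does in this assay, so only a small move toward lower numbers, within the scatter, is expected: the estimate is a 1.4-fold lower number from compound 2 to compound 3 (0.16 log units; within the scatter). The expected value for compound 3 is 3000 nM, with an estimated range of 1000 nM to 9000 nM.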

Compound 3, concentration for 50% growth inhibition: > 50000 nM
Compound 3: no number, only a limit; the forecaster's own chance of this, stated with the estimate: 5%; middle value at least 16-fold (1.22 log units) from the limit.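

In this assay, phenyl in place of methyl on a saturated chain carbon bound to a saturated ring carbon gives an at least 11-fold higher number from compound 2 to compound 3 (1.06 log units; beyond the scatter), the first step read at this position. It shows that the group at this place can decide whether any growth inhibition is seen within the tested range. The value of compound 3 is a limit and not a number, so the true size of the step stays unknown: the limit of > 50000 nM in this assay, at which 1 of the 3 values shown sits.

The compounds shown leave open whether an amine, a carboxylic acid or a longer alkyl chain at this place would keep the growth inhibition of compound 2. They also leave open whether the same change would act alike with a hydroxyl in place of the carbonyl.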